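The source may report more compounds than this note shows. Statements on the series, on what has been measured and on what is new or still open speak of the compounds shown alone.

Compound 3 `CCCCCCCCCCCCCCCCCCNC(=O)[C@@H](NC(=O)c1ccccc1)[C@@H](C)O` is the point of departure. In a functional assay on SiHa cells (Homo sapiens) for cytotoxicity, read by MTT assay, with a stated time of 48 h (a lower number here means a stronger inhibitor, a higher number a weaker inhibitor), compound 3 gives 38200 nM, the lowest of the three numbers, though the others lie close: compound 1 `CCCCCCCCCCCCCCCCCCNC(=O)[C@@H](N)[C@@H](C)O` gives 39500 nM, and compound 2 `CCCCCCCCCCCCNC(=O)[C@@H](NC(=O)c1nccc2ccccc12)[C@@H](C)O` gives 56600 nM; both gaps sit within the scatter, so the three cannot be told apart. Among the measured compounds shown here, the one single-point step among them, a 1.0-fold lower number from compound 1 to compound 3 (0.01 log units; within the scatter), shows that attaching the benzoyl group to the amine nitrogen left the number essentially where it was.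

Compound 4 `CCCCCCCCCCCCCCCCCCNC(=O)[C@@H](NC(=O)c1nccc2ccccc12)[C@@H](C)O` takes the next step from compound 3: isoquinolin-1-yl in place of phenyl on a carbonyl carbon. For the measured compounds named here, no measured pair isolates this exchange. Going by the values given here, the only other bearer of the isoquinolin-1-yl group, compound 2, differs from compound 4 in more than one place, so its number set against that of compound 3 shows only two values within the scatter of one another. With the benzoyl step flat and the isoquinolinyl bearer indistinguishable from compound 3, nothing here points to a move beyond the scatter in this assay.

Compound 4 is therefore expected to give, in this assay, about 45000 nM, with a range from 20000 nM to 100000 nM. For compound 4 the expected step is a 1.2-fold higher number from compound 3 to compound 4 (0.07 log units; within the scatter), essentially none.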

Compound 4, half-maximal inhibitory concentration: 51200 nM
The estimate for compound 4 lay 1.1-fold (0.06 log units) below the measured number; the measured number falls inside the stated range.
By their numbers in this assay, from the lowest: compounds 3, 1, 4 and 2 (each within the scatter of the next).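

In this assay, the exchange of phenyl for isoquinolin-1-yl on a carbonyl carbon now has a measured pair of its own, and a 1.3-fold higher number from compound 3 to compound 4 (0.13 log units; within the scatter) shows that the added nitrogen-bearing ring leaves compound 4 within the scatter of compound 3. Two further single-place comparisons agree: hexyl in place of hydrogen on a saturated chain carbon gives a 1.1-fold lower number from compound 2 to compound 4 (0.04 log units; within the scatter), and the whole (isoquinolin-1-yl)carbonyl group in place of hydrogen on the amine nitrogen gives a 1.3-fold higher number from compound 1 to compound 4 (0.11 log units; within the scatter), both within the scatter. No measurement is available that would explain this flat picture.

On these data alone, what stays open is whether any group at this position can move the number beyond the scatter, for instance a benzoyl carrying a carboxylic acid or an amine in place of the plain phenyl. As far as these compounds go, it is also open whether the isoquinolin-1-yl group would stay equally flat on a much shorter chain than that of compound 2, such as a butyl chain.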